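A few compounds are considered here, and "the series" means these few. Any claim that something is new, unique, unknown or untested is made for them only; others in the source may bear on it.

Measured in an ADME assay on BaF3 cells (Mus musculus) for inhibition, read by CellTiter-Glo, with a stated time of 72 h; on this read-out lower numbers stand for stronger inhibition of growth and higher numbers for weaker inhibition of growth:

Compound 1 `Cc1ccc(NC(=O)c2cccc(C(F)(F)F)c2)cc1N1Cc2cnc(NC3CC3)nc2N(C)C1=O`: 5060 nM
Compound 2 `Cc1ccc(Nc2ncc3c(n2)N(C2CC2)C(=O)N(c2cc(NC(=O)c4ccc(C)c(C(F)(F)F)c4)ccc2C)C3)cn1`: 649 nM
Compound 3 `Cc1ccc(Nc2ncc3c(n2)N(C)C(=O)N(c2cc(NC(=O)c4cc(-n5cnc(C)c5)cc(C(F)(F)F)c4)ccc2C)C3)cn1`: > 5000 nM (a limit of the assay, not a number)

Only two of these three results are true numbers, and compound 2, at 649 nM, has the lower of them. The gap to compound 1, at 5060 nM, lies beyond the scatter of repeated measurements. Compound 3 gives only a limit, > 5000 nM, so it has no exact place in this order.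

The next compound to be tested in this assay is compound 4 `CCN1C(=O)N(c2cc(NC(=O)c3ccc(C)c(C(F)(F)F)c3)ccc2C)Cc2cnc(Nc3ccc(C)nc3)nc21`. It departs from compound 2 in a single place, with ethyl in place of cyclopropyl on an amide-type nitrogen in a ring. Among the compounds with values here, no two measured compounds differ by one change alone, so the data give no direct measure of this swap. The only firm starting point is compound 2 at 649 nM, and no step beyond the scatter is expected in either direction. The estimated step, a 1.1-fold higher number from compound 2 to compound 4 (0.03 log units; within the scatter), is therefore expected to remain within the scatter. For compound 4 the estimated value is 700 nM, with an expected range of 220 nM to 2200 nM.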

Compound 4, concentration for 50% growth inhibition: 708 nM
Estimate against measurement, compound 4: 1.0-fold (0.00 log units) below; measured number inside the range.
By their numbers in this assay, from the lowest: compounds 2 and 4 (each within the scatter of the next); then compound 1.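

Within the data shown here, the pair gives the first direct reading of a change on this amide-type nitrogen in a ring, which the earlier compounds could not give, as no two of them differed in one place alone. In this assay, ethyl in place of cyclopropyl gives a 1.1-fold higher number from compound 2 to compound 4 (0.04 log units; within the scatter), so in this pair, the three-membered ring of carbon can give way to an open chain, with 2 heavy atoms in place of 3, without a step beyond the scatter. The measurements shown offer no explanation for this result.

The compounds shown leave open how far this position accepts other groups, as only cyclopropyl and ethyl have been compared here, and a longer chain such as butyl, or a chain ending in an amine or a carboxylic acid, could read quite differently. From the compounds shown here alone, the step also rests on one pair with the rest of compound 2 held constant, so whether the same swap would read alike on a different amide or a different group on the shared core remains unknown.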